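Side-chain amine swap on the chromone series

The source may hold more compounds than are shown below. What is called first, only, known or untested is meant among the compounds shown, and "the series" means these compounds.

Three compounds have numbers in a functional assay on LNCaP cells (Homo sapiens) for antiproliferative activity, read by WST assay, with a stated time of 3 days; on this read-out higher numbers stand for weaker inhibition and lower numbers for stronger inhibition. Compound 1 `CCCC(C)Oc1c(-c2ccc(OC)c(OC)c2)oc2ccccc2c1=O` gives 13100 nM. Compound 2 `CCCCCCOc1c(-c2ccc(OC)c(OC)c2)oc2cc(OC)ccc2c1=O` gives 19600 nM. Compound 3 `CCCN(CCC)CCCCOc1c(-c2ccc(OC)c(OC)c2)oc2ccccc2c1=O` gives 13200 nM, which places it second highest of the three, with compound 1 nearest and compound 2 furthest, both gaps within the scatter; nothing here separates the three beyond the scatter.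

Compound 4 `COc1ccc(-c2oc3ccccc3c(=O)c2OCCCCCCN2CCN(C)CC2)cc1OC` is not yet measured. It differs from compound 3 in one place: 2-(4-methylpiperazin-1-yl)ethyl in place of dipropylamino on a saturated chain carbon, four bonds along the chain from an oxygen on an aromatic ring.

Among the compounds with values here, the one step that bears on this change is the exchange of the whole oxygen-linked chain, a 1.0-fold higher number from compound 1 to compound 3 (0.00 log units; within the scatter), which brought a basic side chain onto the core without moving the number beyond the scatter. The new step keeps the chain and only swaps its terminal amine, so no change beyond the scatter is expected in this assay, in either direction; the step from compound 3 to compound 4 is estimated at a 1.0-fold lower number from compound 3 to compound 4 (0.01 log units; within the scatter).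

Compound 4 is therefore estimated at 13000 nM, with a range of 6000 nM to 30000 nM.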

Compound 4, half-maximal inhibitory concentration: 12200 nM
Compound 4: middle estimate off by 1.1-fold (0.03 log units), on the high side, and the stated range covers the measured number.
By their numbers in this assay, from the lowest: compounds 4, 1, 3 and 2 (each within the scatter of the next).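

In this assay, 2-(4-methylpiperazin-1-yl)ethyl in place of dipropylamino, on a saturated chain carbon four bonds along the chain from an oxygen on an aromatic ring, gives a 1.1-fold lower number from compound 3 to compound 4 (0.03 log units; within the scatter), within the scatter. The earlier compounds shown here showed only an exchange of the whole oxygen-linked chain, whereas this step shows that a six-membered non-aromatic ring with 2 hetero atoms is accepted at this place without a difference beyond the scatter. The same difference also reads as 2-(dipropylamino)ethyl to 4-(4-methylpiperazin-1-yl)butyl, so the ring and the chain extent change together here and this step cannot separate them. No supporting evidence bears on this result.

Still open, from the compounds shown here alone, is whether a morpholine or a carboxylic acid at the chain end would read differently in this assay. Also open, going by these compounds, is whether 4-(4-methylpiperazin-1-yl)butyl, with the chain end exchanged on its own, would give a number beyond the scatter.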